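The source may hold more compounds than are shown below. What is called first, only, known or untested is meant among the compounds shown, and "the series" means these compounds.

In a physicochemical assay for lipophilicity, at pH 7.4 (a higher number here means a more lipophilic compound, a lower number a more polar compound), compound 1 `CS(=O)(=O)N1C[C@H](C(=O)Nc2ccc3[nH]ccc3c2)[C@@H](C(=O)Nc2ccc(-n3ccccc3=O)cc2F)C1` gives 1.07, compound 2 `COc1ccc(NC(=O)[C@H]2CN(S(C)(=O)=O)C[C@@H]2C(=O)Nc2ccc(-n3ccccc3=O)cc2F)cc1` gives 1.19 and compound 3 `COc1ccc(NC(=O)[C@H]2CN(S(C)(=O)=O)C[C@@H]2C(=O)Nc2ccc(-n3ccccc3=O)cc2F)cc1Cl` gives 1.9, so compound 3 stands highest of the three. Compound 4 `COc1ccc(NC(=O)[C@H]2CN(S(C)(=O)=O)C[C@@H]2C(=O)Nc2ccc(-n3ccccc3=O)cc2F)cc1F` has not yet been measured. It carries fluoro in place of chloro on an aromatic carbon, ortho to a methoxy group and meta to a large group: fluoro in place of chloro on an aromatic carbon. Among the measured compounds shown here, no measured step involves fluoro. The closest guide is a number 0.71 log units higher from compound 2 to compound 3 (beyond the scatter), chloro in place of hydrogen, and a number 0.83 log units higher from compound 1 to compound 3 (beyond the scatter) bears on it less directly. On the strength of a number 0.71 log units higher from compound 2 to compound 3 (beyond the scatter), compound 4 is expected to fall back towards compound 2 in this assay. The expected change is a number 0.55 log units lower from compound 3 to compound 4 (beyond the scatter). For compound 4 the estimated value is 1.35, within an expected range from 1.1 to 1.65.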

Compound 4, distribution coefficient: 0.56
For compound 4 the middle estimate is 0.79 log units above the measured one; measured number below the stated range.
By their numbers in this assay, from the lowest: compound 4; then compounds 1 and 2 (each within the scatter of the next); then compound 3.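

In this assay the two halogens ortho to a methoxy group part ways: chloro in place of hydrogen gave a number 0.71 log units higher from compound 2 to compound 3 (beyond the scatter) while fluoro in place of hydrogen gave a number 0.63 log units lower from compound 2 to compound 4 (beyond the scatter) so that exchanging chloro for fluoro gives a number 1.34 log units lower from compound 3 to compound 4 (beyond the scatter) and exceeds either step alone. The same reversal appears against 1H-indol-5-yl, where 3-chloro-4-methoxyphenyl gave a number 0.83 log units higher from compound 1 to compound 3 (beyond the scatter) and 3-fluoro-4-methoxyphenyl gave a number 0.51 log units lower from compound 1 to compound 4 (beyond the scatter) in the opposite direction. Nothing shown here accounts for this reversal.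

From the compounds shown here alone, whether bromo, methyl or an amine at this place would follow chloro or fluoro remains open.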